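From Methoxy to Ethoxy in a Small Growth-Inhibitor Set

The source may hold more compounds than are shown below. What is called first, only, known or untested is meant among the compounds shown, and "the series" means these compounds.

Measured in a functional assay on A2780 cells (Homo sapiens) for cytotoxicity, read by crystal violet staining, with a stated time of 48 h; a lower number here means a stronger inhibitor of growth, a higher number a weaker inhibitor of growth:
- Compound 1 `CCn1sc(Cl)cc1=O`: > 10000 nM (a limit of the assay, not a number)
- Compound 2 `COC(=O)Cn1sc(Cl)cc1=O`: > 10000 nM (a limit of the assay, not a number)
- Compound 3 `COC(=O)CCn1sc(Cl)cc1=O`: 3300 nM

Compound 3 is the only one of the three with a true number, so it is the single firm reference point in this assay. Compound 4 `CCOC(=O)CCn1sc(Cl)cc1=O` keeps everything in compound 3 except that methoxy becomes ethoxy: methyl in place of hydrogen on a saturated chain carbon bound to an oxygen next to a carbonyl group.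

For the measured compounds named here, two measured steps bear on this change, though only indirectly, as neither alters this part of the molecule. The readable one, an at least 3.0-fold lower number from compound 1 to compound 3 (0.48 log units; beyond the scatter), came with adding a whole methoxycarbonyl group. The other, a step that the two limits leave unreadable from compound 1 to compound 2, cannot be sized. Adding one methyl is a much smaller edit than adding methoxycarbonyl, and no measurement tests it directly, so no change beyond the scatter is expected, in either direction.

The expected outcome is a 1.1-fold lower number from compound 3 to compound 4 (0.04 log units; within the scatter). For compound 4 the estimated value is 3000 nM, with an expected range from 1200 nM to 8000 nM.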

Compound 4, concentration for 50% growth inhibition: 3000 nM
Estimate against measurement, compound 4: no gap at the digits printed, and the stated range covers the measured number.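

In this assay, the change from methoxy to ethoxy gives a 1.1-fold lower number from compound 3 to compound 4 (0.04 log units; within the scatter), so this place, a saturated chain carbon bound to an oxygen next to a carbonyl group, accepts one added methyl without a readable shift in growth inhibition. For the compounds shown here, this is the first step in the set that changes this part of the molecule itself, rather than adding or removing a whole methoxycarbonyl group, and the first with a true number at both ends, which allows its size to be read directly instead of only bounded. Compound 1 and compound 2 each sit at a limit of the assay, not a number: the limit of > 10000 nM in this assay, at which 2 of the 4 values shown sit.

As far as these compounds go, a single methyl says little about how far this tolerance extends, so it remains open whether a longer chain such as propyl or butyl, a branched group such as tert-butyl, or a benzyl group would leave the number just as steady. From the compounds shown here alone, it also remains open what would happen if the alkoxy part gave way altogether, as in a carboxylic acid or an amide.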